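A few compounds are considered here, and "the series" means these few. Any claim that something is new, unique, unknown or untested is made for them only; others in the source may bear on it.

Series notes. In a functional assay on a cell-free system (plasma, Oryctolagus cuniculus) for inhibition of platelet-activating factor acetylhydrolase (Homo sapiens), tested at 100 nM (a higher number here means more inhibition at the concentration tested (going by the name of the read-out), a lower number less inhibition), compound 2 `CCCCCCCCCCCCN(C)C(=O)Cn1cc(Cc2cnc(O)nc2)c(=O)nc1SCc1ccc(F)cc1` gives 39%, the highest of the three numbers in hand. Compound 1 `CCCCCCCCN(C)C(=O)Cn1cc(Cc2cnc(O)nc2)c(=O)nc1SCc1ccc(F)cc1` gives 34% in this assay, and the step of a number 5 percentage points higher from compound 1 to compound 2 (within the scatter) lies within the scatter, so compound 1 and compound 2 are not separated. Compound 3 `CCCCCCCCN(C)C(=O)Cn1cc(Cc2cnc(=O)n(CC(=O)O)c2)c(=O)nc1SCc1ccc(F)cc1` gives 27% in this assay, a value beyond the scatter below compound 2; the step of a number 7 percentage points lower from compound 1 to compound 3 (within the scatter) is within the scatter.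

Compound 4 `CCCCCCCCCCCCN(C)C(=O)Cn1cc(Cc2cnc(=O)n(CCO)c2)c(=O)nc1SCc1ccc(F)cc1` has not yet been measured. The change from compound 2 is a group of 10 heavy atoms (6 carbon, 2 nitrogen, 2 oxygen; one six-membered aromatic ring with 2 hetero atoms) in place of a group of 7 heavy atoms (4 carbon, 2 nitrogen, 1 oxygen; one six-membered aromatic ring with 2 hetero atoms), on a saturated chain carbon bound to an aromatic carbon. Within the data shown here, the one measured step bearing on it is the change on the same carbon from compound 1 to compound 3, which was small, a number 7 percentage points lower from compound 1 to compound 3 (within the scatter), and within the scatter. Nothing else in the set touches that position. The expected step is therefore small, estimated as a number 5 percentage points lower from compound 2 to compound 4 (within the scatter), with a slight lean downward and no change beyond the scatter expected. For compound 4 the estimate in this assay is 34%, with a range of 20% to 48%.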

Compound 4, a percentage reported as inhibition, at one concentration (the size of the read-out at that concentration, not a potency): 36%
Compound 4: the middle estimate sits 2 percentage points below what was measured; the measured number falls inside the stated range.
By their numbers in this assay, from the lowest: compounds 3, 1, 4 and 2 (each within the scatter of the next, the first and the last beyond it).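

At the saturated chain carbon bound to an aromatic carbon, the larger group of compound 4 leaves the read-out in this assay close to that of its parent on the longer amide chain, with a number 3 percentage points lower from compound 2 to compound 4 (within the scatter). The earlier step at this place, a number 7 percentage points lower from compound 1 to compound 3 (within the scatter), was read on the shorter amide chain and with a different entering group, so a small step here now holds on both chains and for both entering groups. Nothing in hand explains why these steps stay small.

As far as these compounds go, it remains open whether an amine in place of the terminal hydroxyl of the entering group, or a longer chain ending in that hydroxyl, would give a step beyond the scatter. Also open, from the compounds shown here alone, is how a group without the six-membered aromatic ring would read at this place.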